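The source may hold more compounds than are shown below. What is called first, only, known or untested is meant among the compounds shown, and "the series" means these compounds.

In a functional assay (aorta) with Rattus norvegicus as the target (a higher number here means a weaker inhibitor, a lower number a stronger inhibitor), three compounds sharing a core have been measured: compound 1 (`CC(C)c1cn2ccccc2c1S(=O)(=O)c1ccc(OCCCN2CCN(c3ccccc3)CC2)cc1`) gives 205 nM, compound 2 (`CC(C)c1cn2ccccc2c1S(=O)(=O)c1ccc(OCCCN2CCC(c3ccccc3)CC2)cc1`) gives 80.9 nM, and compound 3 (`CCCCN(CCCC)CCCCOc1ccc(S(=O)(=O)c2c(C(C)C)cn3ccccc23)cc1`) gives 20.2 nM, the lowest of the three. Compound 4 (`COc1ccc(NCCCOc2ccc(S(=O)(=O)c3c(C(C)C)cn4ccccc34)cc2)cc1OC`) remains unmeasured and departs from compound 3 as follows: (3,4-dimethoxyphenyl)amino in place of (dibutylamino)methyl on a saturated chain carbon, three bonds along the chain from an oxygen on an aromatic ring. For the measured compounds named here, the steps that bear on this are a 10-fold lower number from compound 1 to compound 3 (1.01 log units; beyond the scatter), which is large, and a 4.0-fold lower number from compound 2 to compound 3 (0.60 log units; beyond the scatter), which is modest. In both, (dibutylamino)methyl replaces a group carrying an aromatic ring, and a 2.5-fold lower number from compound 1 to compound 2 (0.40 log units; beyond the scatter) shows that such groups also differ among themselves. As the entering group also carries an aromatic ring, a modest to large rise in the number is expected. The expected change is a 5.9-fold higher number from compound 3 to compound 4 (0.77 log units; beyond the scatter). Compound 4 is estimated at 120 nM, within an expected range of 30 nM to 500 nM.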

Compound 4, half-maximal inhibitory concentration: 396 nM
Compound 4: the middle estimate sits 3.3-fold (0.52 log units) below what was measured; the measured number falls inside the stated range.
By their numbers in this assay, from the lowest: compound 3; then compound 2; then compounds 1 and 4 (each within the scatter of the next).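

In this assay, a third group carrying an aromatic ring also gives a higher number than (dibutylamino)methyl at this saturated chain carbon, with a 20-fold higher number from compound 3 to compound 4 (1.29 log units; beyond the scatter). Among the ring-bearing groups, (3,4-dimethoxyphenyl)amino stands apart from 4-phenylpiperidin-1-yl, with a 4.9-fold higher number from compound 2 to compound 4 (0.69 log units; beyond the scatter), but a 1.9-fold higher number from compound 1 to compound 4 (0.29 log units; within the scatter) does not separate it from 4-phenylpiperazin-1-yl.

No measurement here explains these differences. The compounds shown also leave open how much of the rise belongs to the two methoxy groups, which a plain phenylamino group would test, and whether a dipropylamino group would stay close to (dibutylamino)methyl.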